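Quinolinyl in place of chlorophenyl on the triazole nitrogen

The compounds below may be only part of what the source reports. "The series", "measured", "known", "first", "only" and "open" are said of these compounds alone.

Compounds measured so far:
compound 1, `CN(CCNCc1cn(-c2cccc(Cl)c2)nn1)CCNc1ccnc2cc(Cl)ccc12`: 9400 nM
compound 2, `CN(CCNCc1cn(Cc2ccccc2)nn1)CCNc1ccnc2cc(Cl)ccc12`: 16000 nM
compound 3, `CN(CCNCc1cn(Cc2nc3cc(Cl)ccc3[nH]2)nn1)CCNc1ccnc2cc(Cl)ccc12`: 65000 nM

The three compounds share a core and differ only in the group attached to the nitrogen of the triazole ring. In a functional assay on HCC827 cells (Homo sapiens) for antiproliferative activity, read by sulforhodamine B assay, with a stated time of 72 h (on this read-out lower numbers stand for stronger inhibition and higher numbers for weaker inhibition), compound 1 gives the lowest number of the three. Its nearest neighbour is compound 2, with a 1.7-fold higher number from compound 1 to compound 2 (0.23 log units; within the scatter), a difference that does not separate the two. Compound 3 is the furthest, with a 6.9-fold higher number from compound 1 to compound 3 (0.84 log units; beyond the scatter), and also a 4.1-fold higher number from compound 2 to compound 3 (0.61 log units; beyond the scatter).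

The unmeasured compound 4, `CN(CCNCc1cn(-c2ccnc3cc(Cl)ccc23)nn1)CCNc1ccnc2cc(Cl)ccc12`, is derived from compound 1 by the change (7-chloroquinolin-4-yl in place of 3-chlorophenyl on an aromatic nitrogen). Among the measured compounds shown here, two measured steps bear on it: the one from compound 1 to compound 2, which was within the scatter, and the one from compound 1 to compound 3, where a bicyclic heteroaromatic group on the same position brought a modest weakening. Compound 4 carries a bicyclic heteroaromatic group bound directly to the ring nitrogen, so a small weakening in this assay seems the more likely direction, though a step within the scatter cannot be excluded. For compound 4 the expected step is therefore a 1.3-fold higher number from compound 1 to compound 4 (0.11 log units; within the scatter), and its expected value is 12000 nM, with a range from 4000 nM to 36000 nM.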

Compound 4, half-maximal inhibitory concentration: 18000 nM
Estimate against measurement, compound 4: 1.5-fold (0.18 log units) below; low and high end bracket the measured number.
By their numbers in this assay, from the lowest: compounds 1, 2 and 4 (each within the scatter of the next); then compound 3.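

In this assay the 7-chloroquinolin-4-yl group on the aromatic nitrogen is not separated from 3-chlorophenyl, with a 1.9-fold higher number from compound 1 to compound 4 (0.28 log units; within the scatter) and no more than the usual scatter, and it is likewise not separated from benzyl, with a 1.1-fold higher number from compound 2 to compound 4 (0.05 log units; within the scatter) as the step. Among the compounds shown here, the position therefore accepts a group of two aromatic rings, one of them with a hetero atom, bound directly to the ring nitrogen without a step beyond the scatter, which the earlier compounds could not show. Having two aromatic rings in the group therefore does not by itself go with the higher number of compound 3, since the only step beyond the scatter here is a 3.6-fold lower number from compound 3 to compound 4 (0.56 log units; beyond the scatter) and compounds 1, 2 and 4 stay together, with compound 3 alone going against them; no measurement offered here accounts for this difference.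

The compounds shown leave open whether the chlorine of the 7-chloroquinolin-4-yl group contributes anything, as the same group without chlorine does not appear among them. They also leave open whether an amine or a carboxylic acid on the aromatic ring, or a longer chain between that ring and the ring nitrogen, would move the number beyond the scatter in either direction.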